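Replacing methylsulfonyl with (trifluoromethyl)carbonyl on an amine nitrogen

A few compounds are considered here, and "the series" means these few. Any claim that something is new, unique, unknown or untested is made for them only; others in the source may bear on it.

Measured in an ADME assay on L02 cells (Homo sapiens) for cytotoxicity, read by MTT assay, with a stated time of 48 h (on this read-out lower numbers stand for stronger inhibition and higher numbers for weaker inhibition), compound 1 `O=C1O[C@@H](CO)CN1c1ccc(-n2cc(-c3ccccn3)cn2)c(F)c1` gives 59 ug/mL as a number. Compound 2 `CS(=O)(=O)NC[C@H]1CN(c2ccc(-n3cc(-c4ccccn4)cn3)c(F)c2)C(=O)O1` reads > 400 ug/mL in this assay and this value is a limit of the assay, not a number. Compound 2 therefore stands at the limit of > 400 ug/mL in this assay, at which 1 of the 2 values shown sits, without an exact position.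

Within the data shown here, the one measured step that bears on what follows is an at least 6.7-fold higher number from compound 1 to compound 2 (0.83 log units; beyond the scatter) and it put methanesulfonamido in place of hydroxy. Compound 3 `O=C1O[C@@H](CNC(=O)C(F)(F)F)CN1c1ccc(-n2cc(-c3ccccn3)cn2)c(F)c1` keeps the amine nitrogen on the saturated chain carbon but carries a different group there, with (trifluoromethyl)carbonyl in place of methylsulfonyl on an amine nitrogen as the difference. Among the measured compounds shown here, no measured step covers this exchange itself, so the expectation rests on that single step and is loose. Given an at least 6.7-fold higher number from compound 1 to compound 2 (0.83 log units; beyond the scatter) compound 3, which also lacks the hydroxy, is expected to stay nearer compound 2 than compound 1. The expected move is an at least 2.0-fold lower number from compound 2 to compound 3 (0.30 log units; that floor lies within the scatter) and it may not exceed the scatter. The estimated value for compound 3 is 200 ug/mL with an expected range of 70 ug/mL to 400 ug/mL in this estimate.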

Compound 3, half-maximal inhibitory concentration: > 400 ug/mL
Compound 3 gave a limit, no number; the forecaster's own chance of this, stated with the estimate: 35%; middle value at least 2.0-fold (0.30 log units) from the limit.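

In this assay, putting ((trifluoromethyl)carbonyl)amino in place of hydroxy on a saturated chain carbon bound to a saturated ring carbon gives an at least 6.7-fold higher number from compound 1 to compound 3 (0.83 log units; beyond the scatter), a move in the same direction as an at least 6.7-fold higher number from compound 1 to compound 2 (0.83 log units; beyond the scatter). The higher number seen on losing the hydroxy therefore does not depend on methylsulfonyl on the amine nitrogen, since it also appears with (trifluoromethyl)carbonyl there, and neither of these two compounds goes against this small pattern. Compound 3 joins compound 2 at a limit of the assay, which is not a number: the limit of > 400 ug/mL in this assay, at which 2 of the 3 values shown sit.

As far as these compounds go, with both compounds at a limit, the step between them cannot be read, and the order of methylsulfonyl and (trifluoromethyl)carbonyl on that amine nitrogen remains unknown. From the compounds shown here alone, it also remains open whether a plain amine or a carboxylic acid on the saturated chain carbon would give a number within the range of the assay, and how such a result would compare with compound 1.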